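The compounds below may be only part of what the source reports. "The series", "measured", "known", "first", "only" and "open" are said of these compounds alone.

- Compound 1 `C#Cc1cccc(Nc2ncnc3cc(NC(=O)/C=C/c4ccccc4)sc23)c1`: 700 nM
- Compound 2 `O=C(/C=C/c1ccc(O)cc1)Nc1cc2c(Nc3ccc(Cl)c(Cl)c3)ncnc2s1`: 300 nM

In a functional assay on PC-3 cells (Homo sapiens) for antiproliferative activity, read by MTT assay, with a stated time of 48 h (a higher number here means a weaker inhibitor, a lower number a stronger inhibitor), compound 2 has the lower number of the two at 300 nM, and its gap to compound 1 lies beyond the usual scatter. Compound 3 `COc1ccc(/C=C/C(=O)Nc2cc3c(Nc4ccc(Cl)c(Cl)c4)ncnc3s2)cc1` differs from compound 2 in one place: methyl in place of hydrogen on an oxygen on an aromatic ring, which turns hydroxy into methoxy. Going by the values given here, no measured pair shows this change, so the expectation in this assay is cautious: a small rise in the number, not beyond the scatter. The estimated change is a 1.3-fold higher number from compound 2 to compound 3 (0.12 log units; within the scatter). For compound 3 the estimated value is 400 nM, with an expected range from 150 nM to 1100 nM.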

Compound 3, half-maximal inhibitory concentration: 790 nM
The estimate for compound 3 lay 2.0-fold (0.30 log units) below the measured number; the range from low to high includes it.
By their numbers in this assay, from the lowest: compound 2; then compounds 1 and 3 (each within the scatter of the next).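

In this assay, going from hydroxy to methoxy on the aromatic ring gives a 2.6-fold higher number from compound 2 to compound 3 (0.42 log units; beyond the scatter). Going by these compounds alone, this is the first direct reading of this position, and it shows that adding a single methyl on this oxygen is enough to weaken the inhibitor. Nothing measured here explains why the number rises.

This rests on one pair of compounds, so it is no general rule. From the compounds shown here alone, whether an amine in place of the hydroxy would keep the lower number, or a longer chain such as ethoxy would raise it further, remains open.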